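The compounds below may be only part of what the source reports. "The series", "measured", "known", "first", "only" and "open" are said of these compounds alone.

Measured compounds in a functional assay on Raji cells (Homo sapiens) for antiproliferative activity, read by CCK-8 assay, with a stated time of 24 h; on this read-out lower numbers stand for stronger inhibition and higher numbers for weaker inhibition:
compound 1, `C=CC(=O)Nc1cccc(Nc2nc(Cl)nc(Nc3ccc(OCCOC)cc3)n2)c1`: "not determined" (no result reported)
compound 2, `C=CC(=O)Nc1cccc(Nc2ncnc(Nc3ccc(C(=O)Nc4ccccn4)cc3)n2)c1`: 15600 nM
compound 3, `C=CC(=O)Nc1cccc(Nc2nc(N)nc(Nc3ccc(OCCOC)cc3)n2)c1`: 18300 nM

Compound 3 gives the highest of the two numbers in this assay; compound 2 lies within the scatter of it, so no order between the two is claimed. Compound 1 has no result in this assay.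

Compound 4, `C=CC(=O)Nc1cccc(Nc2ncnc(Nc3ccc(OCCOC)cc3)n2)c1`, differs from compound 3 by hydrogen in place of amino on an aromatic carbon. Within the data shown here, no step between measured compounds is known that would show the size of such a change. With only the value of compound 3 to go on, compound 4 is expected to stay close to it, a step of a 1.1-fold lower number from compound 3 to compound 4 (0.06 log units; within the scatter), none beyond the scatter. Compound 4 is estimated at 16000 nM, in the range 5000 nM to 50000 nM.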

Compound 4, half-maximal inhibitory concentration: 105000 nM
Compound 4: middle estimate off by 6.6-fold (0.82 log units), on the low side, and the stated range ends below it.
By their numbers in this assay, from the lowest: compounds 2 and 3 (each within the scatter of the next); then compound 4.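

In this assay, the amino group on the aromatic carbon between two ring nitrogen atoms now has a measured step: hydrogen in its place gives a 5.7-fold higher number from compound 3 to compound 4 (0.76 log units; beyond the scatter). With hydrogen at that carbon, the other substituent also counts, as 2-methoxyethoxy in place of (pyridin-2-yl)carbamoyl gives a 6.7-fold higher number from compound 2 to compound 4 (0.83 log units; beyond the scatter). Nothing available explains either step.

As far as these compounds go, whether a methylamino or a hydroxy group at this carbon would track compound 3 or compound 4 remains open. So does whether amino would give a similar step alongside (pyridin-2-yl)carbamoyl.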